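Changing the 2,4-dimethoxyphenyl group of compound 2

The source may report more compounds than this note shows. Statements on the series, on what has been measured and on what is new or still open speak of the compounds shown alone.

Compound 1 `CCCCc1oc2ccc(/N=C/c3ccc(Cl)cc3)cc2c1C(=O)c1ccc(OC)cc1` and compound 2 `CCCCc1oc2ccc(/N=C/c3ccc(OC)cc3OC)cc2c1C(=O)c1ccc(OC)cc1` share a core and differ in the group on a carbon with a double bond to nitrogen. In a functional assay, with a stated time of 30 min (a lower number here means a stronger inhibitor, a higher number a weaker inhibitor), compound 1 gives 75.9 ug/mL. Compound 2 gives 20.5 ug/mL, the lower of the two numbers. Compound 3 `CCCCc1oc2ccc(/N=C/c3ccc(OCC)c(OC)c3)cc2c1C(=O)c1ccc(OC)cc1` changes the same group: 4-ethoxy-3-methoxyphenyl in place of 2,4-dimethoxyphenyl on a carbon with a double bond to nitrogen. Within the data shown here, only one measured step bears on this place, a 3.7-fold lower number from compound 1 to compound 2 (0.57 log units; beyond the scatter), when 2,4-dimethoxyphenyl replaced 4-chlorophenyl. That modest step shows that the number can respond to a change here. Among the measured compounds shown here, the new swap is milder on paper, since both groups are phenyl rings carrying alkoxy groups, though no measurement yet tests it. In this assay the expected change is therefore small, a 1.5-fold higher number from compound 2 to compound 3 (0.17 log units; within the scatter), with no shift beyond the scatter anticipated. The estimated value for compound 3 is 30 ug/mL, with an expected range from 12 ug/mL to 75 ug/mL.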

Compound 3, half-maximal inhibitory concentration: 14.8 ug/mL
Compound 3: the middle estimate sits 2.0-fold (0.31 log units) above what was measured; the range from low to high includes it.
By their numbers in this assay, from the lowest: compounds 3 and 2 (each within the scatter of the next); then compound 1.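

In this assay, swapping 2,4-dimethoxyphenyl for 4-ethoxy-3-methoxyphenyl gives a 1.4-fold lower number from compound 2 to compound 3 (0.14 log units; within the scatter) and so these two alkoxy-bearing phenyl rings cannot be told apart at this position. Measured against the 4-chlorophenyl group, the new ring gives a 5.1-fold lower number from compound 1 to compound 3 (0.71 log units; beyond the scatter) and so the clear separation from the chloro compound no longer rests on the 2,4-dimethoxyphenyl group alone. Nothing measured here gives a reason for these numbers.

The compounds shown leave open whether a ring with a single alkoxy group, such as 4-methoxyphenyl, would keep this separation from the 4-chlorophenyl group or whether two such groups are needed. In this assay they also leave open how a ring carrying a hydroxy group, an amine or an alkoxy chain longer than ethoxy would read.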